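Benzyl variations on a shared core: cytotoxicity notes

This account rests on a few compounds, and the source may have more. Where it says the series, first, only, none or still open, it means among the compounds named here.

Measured so far:
Compound 1 `Cc1ccccc1Cn1ccc2nc(-c3ccccc3)nc-2c1`. In an ADME assay on MDBK cells (Bos taurus) for cytotoxicity (on this read-out lower numbers stand for higher toxicity in this test and higher numbers for lower toxicity in this test), compound 1 gives > 100000 nM, a limit of the assay.
Compound 2 `Fc1ccc(Cn2ccc3nc(-c4ccccc4)nc-3c2)cc1`. In this assay compound 2 gives > 100000 nM, also a limit.
Compound 3 `Clc1ccc(Cn2ccc3nc(-c4ccccc4)nc-3c2)cc1`. In this assay compound 3 gives > 100000 nM, also a limit.

Compound 1 thus stands only at a limit, with no number of its own, and the two further values shown are limits as well (the limit of > 100000 nM in this assay, at which 3 of the 3 values shown sit). The steps a step that the two limits leave unreadable from compound 1 to compound 2 and a step that the two limits leave unreadable from compound 1 to compound 3, both changes at the same saturated chain carbon bound to an aromatic nitrogen, cannot be sized. Compound 4 `c1ccc(CCCn2ccc3nc(-c4ccccc4)nc-3c2)cc1` carries the next change at that place: phenethyl in place of 2-methylphenyl on a saturated chain carbon bound to an aromatic nitrogen. No measured step sizes this change, and every value sits at the limit, so no move beyond the scatter is expected in this assay. Compound 4 is therefore expected to give 150000 nM (range 50000 nM to 500000 nM), most likely again as a limit. The step that the limit leaves unreadable from compound 1 to compound 4 is estimated to be small.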

Compound 4, half-maximal cytotoxic concentration: > 100000 nM
Compound 4: no number, only a limit (the forecaster's own chance of this, stated with the estimate: 85%); the middle value does not contradict the limit.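

Among the compounds shown here, no step among compound 1, compound 2, compound 3 and compound 4 can be read, all four resting at one limit: the limit of > 100000 nM in this assay, at which 4 of the 4 values shown sit. Left open is whether any change on the saturated chain carbon bound to an aromatic nitrogen would give a readable number in this assay.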